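The source may report more compounds than this note shows. Statements on the series, on what has been measured and on what is new or still open speak of the compounds shown alone.

Measured compounds:
compound 1, `COc1ccc2cc(/C=C3\CCCN=C3c3cccnc3)ccc2c1` — 600 nM
compound 2, `C(=C1\CCCN=C1c1cccnc1)\c1ccc(-n2ccnn2)cc1` — 520 nM
compound 3, `Cc1cc(/C=C2\CCCN=C2c2cccnc2)cc(C)c1O` — 360 nM

All three values come from an assay on membranes from brain for displacement of a labelled ligand from Neuronal acetylcholine receptor; alpha4/beta2 (Rattus norvegicus), with a stated time of 3 h; a higher number here means a weaker inhibitor, a lower number a stronger inhibitor. Compound 2 stands second highest of the three numbers; its nearest neighbour is compound 1, and compound 3 lies furthest from it, but both gaps fall within the usual scatter, so the three compounds cannot be ranked against each other on these numbers.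

Compound 4, `C(=C1\CCCN=C1c1cccnc1)\c1ccccc1`, has not yet been measured. It differs from compound 2 in one place: hydrogen in place of 1H-1,2,3-triazol-1-yl on an aromatic carbon. For the measured compounds named here, no pair of measured compounds in the set differs in a single place, so there is no measured step of this kind to lean on.

With the three measured compounds sitting close together, the expectation is a moderate step, most likely toward a higher number, though a result within the scatter of compound 2 would not be surprising. The estimate for compound 4 in this assay is 800 nM, with a range from 300 nM to 2500 nM. This estimate corresponds to an expected step of a 1.5-fold higher number from compound 2 to compound 4 (0.19 log units; within the scatter).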

Compound 4, inhibition constant: 850 nM
The estimate for compound 4 lay 1.1-fold (0.03 log units) below the measured number; low and high end bracket the measured number.
By their numbers in this assay, from the lowest: compounds 3, 2, 1 and 4 (each within the scatter of the next, the first and the last beyond it).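

In this assay, for the compounds shown here, hydrogen in place of 1H-1,2,3-triazol-1-yl on an aromatic carbon, para to a large group, gives a 1.6-fold higher number from compound 2 to compound 4 (0.21 log units; within the scatter) and is the only one-place step in the set. At this position, therefore, compound 2 with its five-membered aromatic ring and compound 4 with a bare hydrogen cannot be told apart on these numbers, so the step offers no sign that the triazolyl group matters for this read-out. No measurement at hand bears on the reason for this result.

Open, on these data alone, is whether an amine or a carboxylic acid on the same aromatic carbon would also stay within the scatter of compound 4. Also open, as far as these compounds go, is whether a single fluorine atom or a longer alkyl chain there would give a step that can be read.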